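The compounds below may be only part of what the source reports. "The series", "measured", "known", "first", "only" and "open" are said of these compounds alone.

Measured compounds
Compound 1, `COc1ccc(-c2nc3cc(C(C)O)ccc3[nH]2)cc1`: in an ADME assay on MT4 cells (Homo sapiens) for cytotoxicity, read by MTT assay, with a stated time of 96 h (on this read-out higher numbers stand for lower toxicity in this test and lower numbers for higher toxicity in this test), compound 1 gives >= 100000 nM, which is a limit of the assay and not a number.
Compound 2, `COc1ccc(-c2nc3cc(C(C)O)ccc3[nH]2)c(OC)c1`: in this assay compound 2 gives >= 100000 nM, again a limit of the assay.
Compound 3, `COc1ccc(-c2nc3cc(/C(C)=N/NC(N)=O)ccc3n2C2CCCCC2)cc1`: in this assay compound 3 stands at "not determined" (no result reported), so no result is reported for it.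

The pair of compound 1 and compound 2 differ in one place, described as methoxy in place of hydrogen on an aromatic carbon. Among the compounds with values here, the step that the two limits leave unreadable from compound 1 to compound 2 cannot be read, because both values sit at the limit of >= 100000 nM in this assay, at which 2 of the 3 values shown sit; the two limits show only that neither compound reaches a measurable toxicity in this test.

Compound 4, `COc1ccc(-c2nc3cc(/C(C)=N/NC(N)=O)ccc3n2C2CCCCC2)c(OC)c1`, has not yet been measured. It differs from compound 3 by methoxy in place of hydrogen on an aromatic carbon, and the place of this change is described word for word as for the change from compound 1 to compound 2, so it is the same change, made here on a different core. The difference between the core of compound 3 and the core of compound 1 is not broken down here.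

Since the same change carried compound 1 to compound 2 without leaving the limit at the limit of >= 100000 nM in this assay, at which 2 of the 3 values shown sit, and compound 3 itself has no value, the expectation for compound 4 rests only on that pair. Compound 4 is therefore expected to sit at the same limit, estimated at 100000 nM, within 50000 nM to 200000 nM.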

Compound 4, half-maximal cytotoxic concentration: 23000 nM
The estimate for compound 4 lay 4.3-fold (0.64 log units) above the measured number, outside the stated range (below it).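

No new step can be read from compound 3 to compound 4: in this assay compound 4 gives 23000 nM, whereas compound 3 stands at "not determined" (no result reported), which leaves nothing to set that value against. The compounds shown leave open whether methoxy in place of hydrogen on an aromatic carbon shifts this read-out at all on the core of compound 3.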